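Thiophene carboxamides: a thiourea on the ring amine

The source may hold more compounds than are shown below. What is called first, only, known or untested is meant among the compounds shown, and "the series" means these compounds.

Compound 1 `NC(=O)c1c(NC(=O)c2ccccc2Cl)sc2c1CCNC2` — 28700 nM
Compound 2 `NC(=O)c1c(NC(=O)c2ccccc2Cl)sc2c1CCN(Cc1ccc(Cl)cc1Cl)C2` — 16300 nM
Compound 3 `NC(=O)c1c(NC(=O)c2cccc([N+](=O)[O-])c2)sc2c1CCN(Cc1c(Cl)cccc1Cl)C2` — 13500 nM

The three measured compounds share one core and differ at the amine nitrogen in the saturated ring and in the aroyl group on the amide. In a functional assay on MKN-74 cells (Homo sapiens) for antiproliferative activity, with a stated time of 24 h (on this read-out higher numbers stand for weaker inhibition and lower numbers for stronger inhibition), compound 1 gives 28700 nM, the highest of the three numbers. Compound 2 sits closest, and the step of a 1.8-fold lower number from compound 1 to compound 2 (0.25 log units; within the scatter) shows that adding 2,4-dichlorobenzyl there did not move the read-out beyond the scatter. For the measured compounds named here, compound 3, with a different aroyl group and a 2,6-dichlorobenzyl group, gives 13500 nM, a number lower than that of compound 1 by more than the scatter; no single-change step connects these two.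

Compound 4 `NC(=O)c1c(NC(=O)c2ccccc2Cl)sc2c1CCN(C(=S)Nc1ccccc1F)C2` is not yet measured. It differs from compound 1 by a group of 10 heavy atoms (7 carbon, 1 nitrogen, 1 fluorine, 1 sulfur; one six-membered aromatic ring of carbon only) in place of a hydrogen atom, on an amine nitrogen in a ring. Going by the values given here, the only measured step that bears on it is the one from compound 1 to compound 2, where a sizeable group at the same nitrogen gave a step within the scatter. The new group is of a different kind, a thiourea bearing an aryl ring rather than a benzyl, so the comparison is loose. On this evidence the expected step of a 1.2-fold lower number from compound 1 to compound 4 (0.08 log units; within the scatter) is small and within the scatter. Compound 4 is therefore estimated at 24000 nM, with a range from 8000 nM to 60000 nM.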

Compound 4, half-maximal inhibitory concentration: 12600 nM
Estimate against measurement, compound 4: 1.9-fold (0.28 log units) above, within the range that was stated.
By their numbers in this assay, from the lowest: compounds 4, 3, 2 and 1 (each within the scatter of the next, the first and the last beyond it).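

In this assay, the aryl thiourea on the amine nitrogen in a ring gives a 2.3-fold lower number from compound 1 to compound 4 (0.36 log units; beyond the scatter) with the aroyl group unchanged, so a group at this position can move the read-out beyond the scatter, though only modestly, which the 2,4-dichlorobenzyl group of compound 2 did not do. Against that benzyl group, the thiourea gives a 1.3-fold lower number from compound 2 to compound 4 (0.11 log units; within the scatter) and so cannot be told apart from it in this read-out: the two groups differ in kind, yet the compounds show no clear difference between them, and only compound 4 stands clearly apart from compound 1. Nothing available here accounts for this result.

Going by these compounds, what a urea would give in place of the thiourea, or a plain phenyl ring in place of the fluorine-bearing ring, remains open, so it cannot be said which part of the new group goes with the step. On these data alone, it is also open whether a small group such as methyl or acetyl on this nitrogen would shift the number at all, and whether the thiourea would act the same way alongside the aroyl group of compound 3.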